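A few compounds are considered here, and "the series" means these few. Any claim that something is new, unique, unknown or untested is made for them only; others in the source may bear on it.

Values measured in a physicochemical assay, read by spectrophotometry, with a stated time of 30 min; a higher number here means a weaker inhibitor, a lower number a stronger inhibitor:
- compound 1 `O=C(CCc1nc2ccccc2c(=O)[nH]1)N/N=C/c1ccc(Cl)cc1`: 381000000 nM
- compound 2 `O=C(CCc1nc2ccccc2c(=O)[nH]1)N/N=C/c1ccccc1`: 734000000 nM

Among the measured compounds shown here, only one measured step connects these compounds: a 1.9-fold higher number from compound 1 to compound 2 (0.28 log units; within the scatter). The change behind it is hydrogen in place of chloro on an aromatic carbon. On these numbers, compound 2 therefore stands level with compound 1.

The next compound, compound 3 `COc1cc(/C=N/NC(=O)CCc2nc3ccccc3c(=O)[nH]2)ccc1O`, keeps the shared core but changes the aromatic group: 4-hydroxy-3-methoxyphenyl in place of phenyl on a carbon with a double bond to nitrogen. In words, this is 4-hydroxy-3-methoxyphenyl in place of phenyl on a carbon with a double bond to nitrogen.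

For the measured compounds named here, the step of a 1.9-fold higher number from compound 1 to compound 2 (0.28 log units; within the scatter) is the only guide, and a weak one, since the new group is one that neither measured compound carries. Going by the values given here, a change this different from the measured one could give a larger step than that one, and nothing measured so far fixes its size. On balance, a moderate move towards a lower number in this assay is expected, and the range must stay wide. The expected move is a 4.9-fold lower number from compound 2 to compound 3 (0.69 log units; beyond the scatter). For compound 3 the estimated value is 150000000 nM, with an expected range from 10000000 nM to 700000000 nM.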

Compound 3, half-maximal inhibitory concentration: 204000000 nM
Compound 3: the middle estimate sits 1.4-fold (0.13 log units) below what was measured; low and high end bracket the measured number.
By their numbers in this assay, from the lowest: compounds 3, 1 and 2 (each within the scatter of the next, the first and the last beyond it).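

In this assay, putting 4-hydroxy-3-methoxyphenyl in place of phenyl on the carbon with a double bond to nitrogen gives a 3.6-fold lower number from compound 2 to compound 3 (0.56 log units; beyond the scatter). Among the compounds shown here, this is the first step here that lies beyond the scatter, so a change of aromatic group at this position can shift the reading by more than repeat measurements would. Against the 4-chlorophenyl group, the same new group gives a 1.9-fold lower number from compound 1 to compound 3 (0.27 log units; within the scatter), so 4-hydroxy-3-methoxyphenyl and 4-chlorophenyl cannot be told apart in this assay, and no evidence is available on what lies behind the step from phenyl.

The hydroxy and methoxy groups enter together, so the compounds shown leave open what each would do alone on the phenyl ring. They also leave open how an aromatic group carrying an amine or a carboxylic acid would read in this assay, or whether a longer chain in place of the aromatic group at this carbon would move the number at all.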